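The compounds below may be only part of what the source reports. "The series", "measured", "known", "first", "only" and "open" are said of these compounds alone.

Measured so far:
- compound 1, `COc1ccc(N2CCN(CCNC(=O)c3cccnc3)CC2)cc1`, with 1620 nM in a functional assay for antagonist activity at Adrenergic receptor alpha-1 (Rattus norvegicus); a lower number here means tighter binding, a higher number weaker binding
- compound 2, `Cc1ccc(N2CCN(CCNC(=O)c3ccncc3)CC2)c(C)c1`, with 85.1 nM in this assay

Compound 2 stands lowest of the two numbers in this assay; the nearest is compound 1, whose higher number lies beyond the scatter of the assay. Among the compounds with values here, the two compounds differ in more than one place, so what the gap shows is only that compound 2 binds more tightly, not which part of the structure carries that.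

Compound 3, `Cc1ccc(N2CCN(CCNC(=O)c3cccnc3)CC2)c(C)c1`, keeps the dimethylphenyl side of compound 2 and changes one thing: pyridin-3-yl in place of pyridin-4-yl on a carbonyl carbon. Within the data shown here, no step in this assay between measured compounds is available for this kind of change. Compound 1 also carries the pyridin-3-yl group and gives the higher number, but it differs from compound 2 elsewhere too, so it gives no clean guide. The change is expected to cost some affinity, yet within a modest step: the estimate for compound 3 in this assay is 150 nM, with a range from 40 nM to 600 nM. That corresponds to an expected step of a 1.8-fold higher number from compound 2 to compound 3 (0.25 log units; within the scatter).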

Compound 3, dissociation constant: 1150 nM
For compound 3 the middle estimate is 7.7-fold (0.88 log units) below the measured one; the whole stated range lies below it.
By their numbers in this assay, from the lowest: compound 2; then compounds 3 and 1 (each within the scatter of the next).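

In this assay, pyridin-3-yl in place of pyridin-4-yl on a carbonyl carbon gives a 14-fold higher number from compound 2 to compound 3 (1.13 log units; beyond the scatter), so this single change between two groups of the same atoms is a large one beyond the scatter, which the earlier pair, differing in more than one place, could not show. With pyridin-3-yl held in both compounds, 2,4-dimethylphenyl in place of 4-methoxyphenyl on an amine nitrogen in a ring gives a 1.4-fold lower number from compound 1 to compound 3 (0.15 log units; within the scatter), which lies within the scatter, so this pair cannot be told apart in this assay and the swap shows no clear effect alongside pyridin-3-yl. Nothing at hand explains why the two pyridinyl groups part so widely.

The compounds shown leave open whether pyridin-4-yl would hold its advantage alongside 4-methoxyphenyl, a pairing that would test whether the two changes act independently of each other. They also leave open where pyridin-2-yl or a plain phenyl ring would stand on the same carbonyl carbon, and so whether the pyridin-4-yl result reflects a gain from that group or a loss with pyridin-3-yl.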